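The source may hold more compounds than are shown below. What is called first, only, known or untested is meant among the compounds shown, and "the series" means these compounds.

Three compounds of one shared family have been examined in an ADME assay on microsomes from liver (Homo sapiens) for metabolic stability; on this read-out higher numbers stand for fast clearance and lower numbers for slow clearance. Compound 1 `COc1cccc([C@H](c2cc3cc(C#N)ccc3nc2OC)[C@@](O)(CCN(C)C)c2cc(SC)nc(SC)c2)c1F` gives 15 uL/min. Compound 2 `COc1nc2ccc(C#N)cc2cc1[C@@H](c1cccc(C)c1F)[C@@](O)(CCN(C)C)c1cc(SC)nc(SC)c1` gives 9.2 uL/min. Compound 3 `CCSc1cc([C@](O)(CCN(C)C)[C@@H](c2cc3cc(C#N)ccc3nc2OC)c2cccc(OC)c2F)cc(SCC)n1` gives 17 uL/min.

Compound 2 differs from compound 1 in one place: methyl in place of methoxy on an aromatic carbon. That change made a 1.6-fold lower number from compound 1 to compound 2 (0.21 log units; within the scatter). Compound 3 differs from compound 1 elsewhere: a group of 12 heavy atoms (9 carbon, 1 nitrogen, 2 sulfur; one six-membered aromatic ring with 1 hetero atom) in place of a group of 10 heavy atoms (7 carbon, 1 nitrogen, 2 sulfur; one six-membered aromatic ring with 1 hetero atom), on a saturated chain carbon bound to an oxygen on a saturated carbon and two saturated chain carbons. That change made a 1.1-fold higher number from compound 1 to compound 3 (0.05 log units; within the scatter).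

Compound 4 `CCSc1cc([C@](O)(CCN(C)C)[C@@H](c2cc3cc(C#N)ccc3nc2OC)c2cccc(C)c2F)cc(SCC)n1` has not yet been measured. It differs from compound 3 by methyl in place of methoxy on an aromatic carbon. For the measured compounds named here, this is the same change as the one from compound 1 to compound 2, at the same place on the ring, only carried out on the core of compound 3 rather than that of compound 1.

Compound 4 is therefore expected to show a 1.5-fold lower number from compound 3 to compound 4 (0.19 log units; within the scatter), because the same change once gave a 1.6-fold lower number from compound 1 to compound 2 (0.21 log units; within the scatter). Going by the values given here, that expectation rests on the single earlier step and on the starting point of compound 3 at 17 uL/min. For compound 4 the estimate in this assay is 11 uL/min, expected to fall between 6 uL/min and 22 uL/min.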

Compound 4, intrinsic clearance in a liver preparation (reported as CLH), per the amount of preparation that the assay uses: 9.1 uL/min
The estimate for compound 4 lay 1.2-fold (0.08 log units) above the measured number; low and high end bracket the measured number.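

In this assay, putting methyl in place of methoxy, read as 2-fluoro-3-methoxyphenyl to 2-fluoro-3-methylphenyl, gives a 1.9-fold lower number from compound 3 to compound 4 (0.27 log units; within the scatter), and this matches the earlier step on the other core: the same change on two cores in this assay, a 1.6-fold lower number (0.21 log units; within the scatter) from compound 1 to compound 2 and a 1.9-fold lower number (0.27 log units; within the scatter) from compound 3 to compound 4, 1.1-fold (0.06 log units) apart, within the scatter of two such steps. The larger of the two sulfur-bearing aromatic groups in place of the smaller one gives a 1.0-fold lower number from compound 2 to compound 4 (0.00 log units; within the scatter), and this step also matches its earlier counterpart: the same change on two cores in this assay, a 1.1-fold higher number (0.05 log units; within the scatter) from compound 1 to compound 3 and a 1.0-fold lower number (0.00 log units; within the scatter) from compound 2 to compound 4, 1.1-fold (0.06 log units) apart, within the scatter of two such steps. Each change therefore behaves alike on the two cores at hand, but all four steps lie within the scatter, so this agreement shows neither that either change has a real effect on clearance nor that it would carry over to any further core.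

As far as these compounds go, it remains open whether a different group in the methoxy position, such as chloro, ethyl or trifluoromethyl, would give a step beyond the scatter. From the compounds shown here alone, it is also open whether a longer chain on the sulfur atoms, such as propyl, would move the number clearly.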